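The compounds below may be only part of what the source reports. "The series", "measured", "known", "first", "only" and "open" are said of these compounds alone.

Compound 1 `CSc1ccc(/C=N/n2c(Cc3ccc(S(C)(=O)=O)cc3)n[nH]c2=S)cc1` – 32.7%
Compound 2 `CS(=O)(=O)c1ccc(Cc2n[nH]c(=S)n2/N=C/c2c(F)cccc2Cl)cc1` – 55.3%

In a functional assay on HeLa cells (Homo sapiens) for cytotoxicity, read by MTT assay, with a stated time of 48 h, tested at 25 uM (on this read-out lower numbers stand for a weaker effect and higher numbers for a stronger effect at the one concentration tested), compound 2 stands highest of the two, ahead of compound 1 by a number 22.6 percentage points higher from compound 1 to compound 2 (beyond the scatter). Compound 3 `CS(=O)(=O)c1ccc(Cc2n[nH]c(=S)n2/N=C/c2ccc(F)cc2)cc1` differs from compound 2 in one place: 4-fluorophenyl in place of 2-chloro-6-fluorophenyl on a carbon with a double bond to nitrogen. Going by the values given here, the only measured step at that position is the one from compound 1 to compound 2, where the 2-chloro-6-fluorophenyl group brought a modest gain. Compound 3 gives up that group, so a modest loss is expected, with the estimated step of a number 15.3 percentage points lower from compound 2 to compound 3 (beyond the scatter). Compound 3 is therefore estimated at 40%, within a range from 25% to 58%.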

Compound 3, a percentage reported as activity, at one concentration (the size of the read-out at that concentration, not a potency): "not active" (no number reported)
No number was reported for compound 3, so the estimate cannot be set against anything.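

Going by these compounds alone, compound 3 is reported only as not active, without a number, so no step from compound 2 to compound 3 can be read. How large the effect of exchanging 2-chloro-6-fluorophenyl for 4-fluorophenyl is remains open, and no other data shown here bear on this result.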